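This account rests on a few compounds, and the source may have more. Where it says the series, first, only, none or still open, it means among the compounds named here.

The study concerns three amides built on one shared core. Compound 1 `O=C(Nc1ccc(Sc2nc3ccccc3s2)cc1)c1cc(Br)cc(Br)c1` carries a 3,5-dibromophenyl on the carbonyl carbon. In an assay on isolated protein for inhibition of thiosulfate sulfurtransferase (Homo sapiens), with a stated time of 60 min, in the absence of a further agent (a higher number here means a weaker inhibitor, a lower number a stronger inhibitor), compound 1 reaches only the limit of the assay, > 100000 nM. Compound 2 `O=C(Nc1ccc(Sc2nc3ccccc3s2)cc1)c1ccccc1O` carries a 2-hydroxyphenyl in the same place. In this assay compound 2 likewise stops at the limit, > 100000 nM. The step that the two limits leave unreadable from compound 1 to compound 2 can therefore not be read in size or direction. Both readings sit at the limit (the limit of > 100000 nM in this assay, at which 2 of the 2 values shown sit), so compound 2 stands at that limit with no number of its own. Compound 3 `O=C(Nc1ccc(Sc2nc3ccccc3s2)cc1)c1cc(Br)cc(Br)c1O` is the compound still to be measured. It differs from compound 2 in one place: 3,5-dibromo-2-hydroxyphenyl in place of 2-hydroxyphenyl on a carbonyl carbon. The only measured step that bears on this change is the unreadable one between compound 1 and compound 2, so no size or direction can be drawn from the numbers shown. Compound 3 is therefore expected to sit at the limit as well, with an estimated 150000 nM spanning 50000 nM to 500000 nM. For compound 3 the expected step is a step that the limit leaves unreadable from compound 2 to compound 3, none beyond the scatter.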

Compound 3, half-maximal inhibitory concentration: > 100000 nM
Compound 3 gave a limit, no number; the forecaster's own chance of this, stated with the estimate: 85%; the middle value is on the limit's open side.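

Compound 3 stops at a limit, as do compound 1 and compound 2, so no step among these three compounds can be read in size or direction: the limit of > 100000 nM in this assay, at which 3 of the 3 values shown sit.

The compounds shown leave open how strongly any of the three inhibits in this assay, and whether the 3,5-dibromo-2-hydroxyphenyl differs at all from the other two groups on the carbonyl carbon.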